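Ring Closure on the Side-Chain Amine

The source may hold more compounds than are shown below. What is called first, only, known or untested is meant among the compounds shown, and "the series" means these compounds.

Among the compounds with values here, compound 2 `CN(C)CCNc1nc(NCc2ccco2)c2ccccc2n1` stands at the lower of the two numbers measured so far. In a functional assay on HT-29 cells (Homo sapiens) for cytotoxicity, read by MTT assay, with a stated time of 2 days, tested at 10 uM (a lower number here means less inhibition, a higher number more inhibition at the concentration tested (going by the name of the read-out)), compound 2 gives 21.7%, whereas compound 1 `CCCCNc1nc(NCc2ccco2)c2ccccc2n1` gives 92.3%. Within the data shown here, the single measured step between them, a number 70.6 percentage points lower from compound 1 to compound 2 (beyond the scatter), is the only change recorded on this part of the molecule. Compound 3 `c1coc(CNc2nc(NCCCN3CCCC3)nc3ccccc23)c1` alters the same chain once more: (pyrrolidin-1-yl)methyl in place of dimethylamino on a saturated chain carbon, two bonds along the chain from a nitrogen on an aromatic ring. Among the measured compounds shown here, no measured step covers this particular exchange. The step from compound 1 to compound 2 shows that what sits two bonds along the chain from the ring nitrogen moves the read-out a great deal, but that step set a nitrogen-bearing end against a plain ethyl end, while compound 3 keeps a chain nitrogen and adds a five-membered ring to it. The expectation is therefore held loosely: compound 3 is estimated to sit somewhat above compound 2, by a number 18.3 percentage points higher from compound 2 to compound 3 (beyond the scatter), with broad uncertainty on both sides. Compound 3 is expected to give about 40%, estimated to fall between 12% and 78%.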

Compound 3, a percentage reported as inhibition, at one concentration (the size of the read-out at that concentration, not a potency): 87.5%
Beside the measured number, compound 3's estimate is 47.5 percentage points below it, and the stated range ends below it.
By their numbers in this assay, from the lowest: compound 2; then compounds 3 and 1 (each within the scatter of the next).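

The exchange of 2-(dimethylamino)ethyl for 3-(pyrrolidin-1-yl)propyl gives, in this assay, a number 65.8 percentage points higher from compound 2 to compound 3 (beyond the scatter) and shows that a nitrogen-bearing chain end does not by itself go with the low read-out of compound 2. The chain of compound 1 and the pyrrolidine-ended chain cannot be told apart here, with a number 4.8 percentage points lower from compound 1 to compound 3 (within the scatter) as the step between them, so this position accepts both a plain saturated chain and one ending in a five-membered non-aromatic ring, while the dimethylamino-ended chain of compound 2 stands alone at the low end. Nothing at hand bears on why the read-out moves in this way.

The step from compound 2 to compound 3 changes the length of the chain and its end group together, so the compounds shown do not say which of the two carries the change; a 3-(dimethylamino)propyl or a 2-(pyrrolidin-1-yl)ethyl chain would separate them. As far as these compounds go, whether other ring amines at the chain end, such as piperidine or morpholine, would read like compound 3 or like compound 2 also remains open.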